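Growth inhibition notes: from compound 2 to compound 3

A few compounds are considered here, and "the series" means these few. Any claim that something is new, unique, unknown or untested is made for them only; others in the source may bear on it.

Of the compounds shown here, two have numbers so far in a functional assay on PC-3 cells (Homo sapiens) for inhibition, read by MTT assay, with a stated time of 48 h, tested at 10 uM; on this read-out higher numbers stand for more inhibition of growth at the one concentration tested and lower numbers for less inhibition of growth. Compound 1 (`Cc1cc(=O)c2c(O)cc(OC/C=C/c3ccccc3)c([C@H]3CCN(C)C[C@H]3O)c2o1`) gives 18%, and compound 2 (`Cc1oc2c([C@H]3CCN(C)C[C@H]3O)c(O)cc(O)c2c(=O)c1C(O)c1ccc(Cl)cc1`) gives 41%. Compound 2 therefore stands highest of the two, and the gap to compound 1 lies beyond the usual scatter. Within the data shown here, these two compounds do not differ in one place only, so their gap gives no measured step to work from.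

Compound 3 (`COc1ccc(C(O)c2c(C)oc3c([C@H]4CCN(C)C[C@H]4O)c(O)cc(O)c3c2=O)cc1Br`) is not yet measured. It differs from compound 2 in one place: 3-bromo-4-methoxyphenyl in place of 4-chlorophenyl on a saturated chain carbon bound to an aromatic carbon and an oxygen on a saturated carbon. This puts 3-bromo-4-methoxyphenyl in place of 4-chlorophenyl on a saturated chain carbon bound to an aromatic carbon and an oxygen on a saturated carbon. Among the measured compounds shown here, the series holds no measured example of this exchange, and nothing in the data sets a direction for it. No shift beyond the scatter is therefore expected, and the estimated step is a number 3 percentage points lower from compound 2 to compound 3 (within the scatter). In this assay the expected value for compound 3 is 38%, with an estimated range from 20% to 58%.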

Compound 3, percent growth inhibition at one concentration: 0%
For compound 3 the middle estimate is 38 percentage points above the measured one, and the stated range ends above it.
By their numbers in this assay, from the lowest: compound 3; then compound 1; then compound 2.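

Among these compounds, the place on a saturated chain carbon bound to an aromatic carbon and an oxygen on a saturated carbon gives the first single-place reading, and the exchange there matters: in this assay 3-bromo-4-methoxyphenyl in place of 4-chlorophenyl gives a number 41 percentage points lower from compound 2 to compound 3 (beyond the scatter) and no further qualification is needed to call it large. The aryl groups at this place are therefore not interchangeable, and the growth inhibition seen with the 4-chlorophenyl group in compound 2 does not carry over to this second substituted phenyl, with compound 3 reading 0% at the one concentration tested. Nothing at hand explains a step of this size.

The exchange alters two features of the ring at once, so the compounds shown do not tell whether the loss goes with the bromine, with the methoxy group or only with the two together; 3-bromophenyl and 4-methoxyphenyl at the same place would separate these. Also open, from the compounds shown here alone, is whether the 4-chlorophenyl group is itself near the best choice here, or whether another group, such as an aminophenyl or a carboxylic acid on the ring, would read higher than compound 2.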